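The source may report more compounds than this note shows. Statements on the series, on what has been measured and on what is new or still open speak of the compounds shown alone.

In an ADME assay on HEK-293T cells (Homo sapiens) for cytotoxicity, read by MTT assay, with a stated time of 48 h (a lower number here means that less compound is tolerated, a higher number that more compound is tolerated), three compounds have been measured, each only as a limit of the assay:

- compound 1 `COc1ccc2c(c1)c(C1CC(c3ccccc3)=NN1C(=O)c1ccc(OC)nc1)cn2C` gives > 300000 nM (a limit)
- compound 2 `COc1ccc2c(c1)c(C1CC(c3ccc(Cl)cc3)=NN1C(=O)c1ccc(OC)nc1)cn2C` gives > 300000 nM (a limit)
- compound 3 `COc1ccc2c(c1)c(C1CC(c3ccc(Br)cc3)=NN1C(=O)c1ccc(OC)nc1)cn2C` gives > 300000 nM (a limit)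

Compound 3 reads > 300000 nM in this assay as a limit and not as a number. Compound 4 `COc1ccc(C2=NN(C(=O)c3ccc(OC)nc3)C(c3cn(C)c4ccc(OC)cc34)C2)cc1` changes one group, 4-bromophenyl to 4-methoxyphenyl, so that methoxy stands in place of bromo on an aromatic carbon, para to a large group; the counted difference is methoxy in place of bromo on an aromatic carbon and nothing else changes.

The measured steps nearest to this change are a step that the two limits leave unreadable from compound 1 to compound 3 and a step that the two limits leave unreadable from compound 2 to compound 3 and neither has a readable size. The same holds for a step that the two limits leave unreadable from compound 1 to compound 2 in this series. Among the compounds with values here, the whole record so far is the limit of > 300000 nM in this assay, at which 3 of the 3 values shown sit, and no compound has yet given a number.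

Since a step that the two limits leave unreadable from compound 2 to compound 3 offers no size to carry over, no step beyond the usual scatter is expected in this assay and no direction can be named. The expected step is a number no higher from compound 3 to compound 4 (the limit leaves the size open) and it remains an estimate. For compound 4 the estimated value is 300000 nM with an expected range from 150000 nM to 450000 nM and a report as a limit is the likeliest outcome.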

Compound 4, half-maximal cytotoxic concentration: > 300000 nM
Compound 4: only a limit was reported (the forecaster's own chance of this, stated with the estimate: 80%); the middle value sits exactly at the limit.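

Compound 4 gives only a limit, as do compound 1, compound 2 and compound 3, so no step among these four can be read in this assay. Open remain the actual half-maximal cytotoxic concentration of each compound and whether hydrogen, chloro, bromo or methoxy on that aromatic carbon changes it.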